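Compound 4: Bromo in Place of Trifluoromethyl

A few compounds are considered here, and "the series" means these few. Any claim that something is new, unique, unknown or untested is made for them only; others in the source may bear on it.

Compound 1, `CCCCCCCCNc1nc(SCc2ccc(C(F)(F)F)cc2)nc2ccccc12`, gives 12600 nM in a functional assay on MGC-803 cells (Homo sapiens) for cytotoxicity, read by MTT assay, with a stated time of 72 h; on this read-out lower numbers stand for stronger inhibition and higher numbers for weaker inhibition.
Compound 2, `FC(F)(F)c1ccc(CSc2nc(Nc3ccccc3C(F)(F)F)c3ccccc3n2)cc1`, reaches only the limit > 50000 nM in this assay.
Compound 3, `FC(F)(F)c1ccc(CSc2nc(Nc3cccc(C(F)(F)F)c3)c3ccccc3n2)cc1`, gives 15100 nM in this assay.

Compound 3 carries the highest of the two numbers given; its nearest neighbour is compound 1, with a 1.2-fold higher number from compound 1 to compound 3 (0.08 log units; within the scatter), a difference that stays within the scatter. Compound 2 sits at the limit of > 50000 nM in this assay, at which 1 of the 3 values shown sits, so it supplies no number to compare against. The step of an at least 3.3-fold lower number from compound 2 to compound 3 (0.51 log units; beyond the scatter) shows that moving the trifluoromethyl around the ring changes the read-out beyond the scatter, while an at least 3.9-fold higher number from compound 1 to compound 2 (0.59 log units; beyond the scatter) shows the same for replacing octyl with the 2-substituted ring.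

Compound 4, `FC(F)(F)c1ccc(CSc2nc(Nc3cccc(Br)c3)c3ccccc3n2)cc1`, differs from compound 3 by bromo in place of trifluoromethyl on an aromatic carbon. Within the data shown here, none of the measured steps swaps one group for another at this position; they concern the position of the trifluoromethyl or the exchange of the whole group on the nitrogen. Among the measured compounds shown here, no step therefore bears directly on the change, and the expectation for this assay is a step of no clear size and no clear direction, a 1.0-fold lower number from compound 3 to compound 4 (0.00 log units; within the scatter), likely within the scatter.

Compound 4 is thus expected to give 15000 nM, with a range from 6000 nM to 40000 nM.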

Compound 4, half-maximal inhibitory concentration: 23700 nM
The estimate for compound 4 lay 1.6-fold (0.20 log units) below the measured number; the measured number falls inside the stated range.
By their numbers in this assay, from the lowest: compounds 1, 3 and 4 (each within the scatter of the next). At a limit, above all of these: compound 2.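

In this assay the exchange on the aromatic carbon itself is now seen directly (a 1.6-fold higher number from compound 3 to compound 4 (0.20 log units; within the scatter)): swapping trifluoromethyl for bromo at this place, with its four heavy atoms giving way to one, leaves the read-out within the scatter. Against the octyl compound the new 3-bromophenyl group also stays within the scatter (a 1.9-fold higher number from compound 1 to compound 4 (0.27 log units; within the scatter)), so compound 1, compound 3 and compound 4 cannot be told apart in this assay, while compound 2, which stands at a limit and has no number, remains apart from compound 4 beyond the scatter (an at least 2.1-fold lower number from compound 2 to compound 4 (0.32 log units; beyond the scatter)). Nothing shown here offers a reason for any of these steps.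

Going by these compounds, whether a chloro, a nitrile or a carboxylic acid on the same aromatic carbon would move the read-out beyond the scatter from compound 3 and compound 4 stays open. Also open, on these data alone, is whether any other group on the nitrogen, such as a longer chain or a chain ending in an amine, would give a number clearly lower than those of these three compounds.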